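The source may report more compounds than this note shows. Statements on the series, on what has been measured and on what is new or still open speak of the compounds shown alone.

Compound 1 `CCc1cc(C(C)=O)c(O)cc1OCCCCC#N` has been tested in an assay on isolated protein for binding affinity to leukotriene B4 receptor 1 (Homo sapiens), tested at 1 uM (on this read-out lower numbers stand for less inhibition and higher numbers for more inhibition at the one concentration tested (going by the name of the read-out)), where compound 1 gives 57%. For the measured compounds named here, this is the highest of the two numbers known so far; the other measured compound, compound 2 `CC(=O)c1cc(C(C)=O)c(OCCCCC#N)cc1O`, gives 0% in this assay, and the one known step, a number 57 percentage points lower from compound 1 to compound 2 (beyond the scatter), comes from acetyl in place of ethyl on an aromatic carbon. Compound 3 `CCc1cc(C(C)=O)c(O)cc1OCCCCCC[S+](C)[O-]` keeps the ethyl and changes the chain instead: a group of 5 heavy atoms (3 carbon, 1 oxygen, 1 sulfur; no ring) in place of a group of 2 heavy atoms (1 carbon, 1 nitrogen; no ring), on a saturated chain carbon, four bonds along the chain from an oxygen on an aromatic ring. Going by the values given here, the step from compound 1 to compound 2 concerns a different place on the shared core and so does not bear on this change; no measured step touches the end of the chain. Lacking any anchor for the direction, the step expected here, a number 7 percentage points lower from compound 1 to compound 3 (within the scatter), is taken as small and uncertain. The estimate for compound 3 in this assay is 50%, between 20% and 80%.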

Compound 3, a percentage reported as inhibition, at one concentration (the size of the read-out at that concentration, not a potency): 50%
Beside the measured number, compound 3's estimate shows no gap at the digits printed, within the range that was stated.
By their numbers in this assay, from the lowest: compound 2; then compounds 3 and 1 (each within the scatter of the next).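

At the end of the chain, on a saturated chain carbon four bonds along the chain from an oxygen on an aromatic ring, this assay now gives a first measured step: a number 7 percentage points lower from compound 1 to compound 3 (within the scatter). So this place accepts the exchange of cyano for a group of 5 heavy atoms (3 carbon, 1 oxygen, 1 sulfur; no ring) with no difference beyond the scatter, and both groups count 0 hydrogen-bond donors and 1 hydrogen-bond acceptor. Nothing measured here explains this result.

The compounds shown leave open whether a carboxylic acid or an amine at the end of the chain would fit as well, since both groups compared here carry no net charge. They also leave open whether a longer chain would give a similar number, and how the two compounds compare in potency, since the read-out comes from one concentration.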